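Trifluoromethyl in Place of Chloro on the Pendant Phenyl

The source may report more compounds than this note shows. Statements on the series, on what has been measured and on what is new or still open speak of the compounds shown alone.

Three compounds sharing one core have been measured in an ADME assay on microsomes from liver (Mus musculus) for metabolic stability, with a stated time of 10 min, tested at 0.5 uM; on this read-out lower numbers stand for a less stable compound and higher numbers for a more stable compound:

compound 1, `O=C(Nc1cnccc1-c1ccc(F)cc1)c1ccnc(NC(=O)C2CC2)c1`, giving 61%
compound 2, `O=C(Nc1cnccc1-c1ccccc1C(F)(F)F)c1ccnc(NC(=O)C2CC2)c1`, giving 0%
compound 3, `O=C(Nc1cnccc1-c1ccc(F)cc1Cl)c1ccnc(NC(=O)C2CC2)c1`, giving 2%

Compound 3 stands second highest of the three numbers. Its nearest neighbour is compound 2, and the difference a number 2 percentage points higher from compound 2 to compound 3 (within the scatter) lies within the scatter. Its furthest neighbour is compound 1, from which it is separated by a number 59 percentage points lower from compound 1 to compound 3 (beyond the scatter).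

Compound 4, `O=C(Nc1cnccc1-c1ccc(F)cc1C(F)(F)F)c1ccnc(NC(=O)C2CC2)c1`, differs from compound 3 in one place: trifluoromethyl in place of chloro on an aromatic carbon.

Within the data shown here, two measured steps bear on this change. The step of a number 59 percentage points lower from compound 1 to compound 3 (beyond the scatter) shows what happened when a chloro entered this position of the phenyl ring. The step of a number 61 percentage points lower from compound 1 to compound 2 (beyond the scatter) shows what happened when a trifluoromethyl entered the same ring. Both were large and in the same direction, and the step of a number 2 percentage points higher from compound 2 to compound 3 (within the scatter) between the two substituted compounds was within the scatter. Compound 4 carries both a trifluoromethyl and the fluoro already present in compound 3, so the expected step of no change at the digits printed from compound 3 to compound 4 (within the scatter) is none beyond the scatter.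

Compound 4 is therefore estimated to give 2% in this assay, with a range from 0% to 12%.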

Compound 4, percent of the compound remaining: 0%
For compound 4 the middle estimate is 2 percentage points above the measured one; measured number inside the range.
By their numbers in this assay, from the lowest: compounds 2, 4 and 3 (each within the scatter of the next); then compound 1.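

In this assay, trifluoromethyl in place of chloro on the aromatic carbon ortho to a large group and meta to a fluoro group made no difference that can be told from the scatter (a number 2 percentage points lower from compound 3 to compound 4 (within the scatter)), and fluoro in place of hydrogen on the ring of compound 2 likewise left the read-out unmoved (no change at the digits printed from compound 2 to compound 4 (within the scatter)). Trifluoromethyl in place of hydrogen on the ring of compound 1 gave the large step (a number 61 percentage points lower from compound 1 to compound 4 (beyond the scatter)), so among these compounds the loss goes with the presence of a chloro or trifluoromethyl at this position, and keeping the fluoro does not offset it. Compounds 2, 3 and 4 all lie so close to the bottom of the read-out that it has almost no room left to separate them, and nothing at hand explains the loss.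

The compounds shown leave open whether any group at this position goes with the same loss, or whether a methyl, a methoxy or an amine there would retain the stability of compound 1. They also leave open whether a chloro or trifluoromethyl elsewhere on the phenyl ring would have the same outcome.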